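The source may hold more compounds than are shown below. What is called first, only, known or untested is meant among the compounds shown, and "the series" means these compounds.

In a functional assay on K562 cells (Homo sapiens) for antiproliferative activity, read by MTT assay, with a stated time of 48 h (on this read-out lower numbers stand for stronger inhibition and higher numbers for weaker inhibition), compound 3 `CN(C)CCCn1c(N)c(-c2nc3ccccc3n2C)c2nc(C#N)c(C#N)nc21` gives 3560 nM and is the higher of the two numbers shown. Compound 1 `CN(C)CCCCn1c(N)c(-c2nc3ccccc3o2)c2nc(C#N)c(C#N)nc21` gives 1380 nM and sits below it. Compound 2 `CN(C)CCn1c(N)c(-c2nc3ccccc3n2C)c2nc(C#N)c(C#N)nc21` reads > 50000 nM and this is a limit of the assay, not a number.

Compound 4 `CN(C)CCCCn1c(N)c(-c2nc3ccccc3n2C)c2nc(C#N)c(C#N)nc21` lengthens the chain from 3-(dimethylamino)propyl to 4-(dimethylamino)butyl ((dimethylamino)methyl in place of dimethylamino on a saturated chain carbon, three bonds along the chain from an aromatic nitrogen), with (dimethylamino)methyl in place of dimethylamino on a saturated chain carbon, three bonds along the chain from an aromatic nitrogen. Going by the values given here, one measured step bears on this: an at least 14-fold lower number from compound 2 to compound 3 (1.14 log units; beyond the scatter) for the same change made two bonds along the chain from an aromatic nitrogen. Among the compounds with values here, compound 1 carries the 4-(dimethylamino)butyl chain on a different core and gives a number (1380 nM) under that of compound 3, though no step links it directly to compound 4. Within the data shown here, a further fall in this assay is therefore expected, but a much smaller one than the single measured step. The estimated step is a 2.4-fold lower number from compound 3 to compound 4 (0.38 log units; beyond the scatter) in this series. Compound 4 is expected at 1500 nM with an estimated range of 400 nM to 6000 nM in this assay for now.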

Compound 4, half-maximal inhibitory concentration: 1450 nM
The estimate for compound 4 lay 1.0-fold (0.01 log units) above the measured number, and the stated range covers the measured number.
By their numbers in this assay, from the lowest: compounds 1 and 4 (each within the scatter of the next); then compound 3. At a limit, above all of these: compound 2.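

In this assay, the number keeps falling as the chain grows past 3-(dimethylamino)propyl, with a 2.5-fold lower number from compound 3 to compound 4 (0.39 log units; beyond the scatter), and across the whole chain set the result is an at least 34-fold lower number from compound 2 to compound 4 (1.53 log units; beyond the scatter). Compound 2 stands at a limit and not at a number, so that wider step is a bound: the limit of > 50000 nM in this assay, at which 1 of the 4 values shown sits. With the 4-(dimethylamino)butyl chain held, 1-methyl-1H-benzimidazol-2-yl in place of 1,3-benzoxazol-2-yl on an aromatic carbon gives a 1.1-fold higher number from compound 1 to compound 4 (0.02 log units; within the scatter), so these two groups are not told apart in this assay.

As far as these compounds go, whether the fall continues with a longer chain, such as 5-(dimethylamino)pentyl, stays open. So does the effect of a different terminal amine, such as morpholine or a primary amine, in place of dimethylamino.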